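A few compounds are considered here, and "the series" means these few. Any claim that something is new, unique, unknown or untested is made for them only; others in the source may bear on it.

Measured compounds:
compound 1 `O=C(C1CCCC1)N1CC2CC(C1)N2` — 68%
compound 2 `O=C(C1CC=CC1)N1CC2CC(C1)N2` — 95%
compound 3 `O=C([C@@H]1C[C@@H]1F)N1CC2CC(C1)N2` — 110%

In an assay on SH-EP1 cells for agonist activity at Neuronal acetylcholine receptor; alpha4/beta2 (Homo sapiens), read by FLIPR and calcium flux (on this read-out higher numbers stand for larger maximal responses and lower numbers for smaller maximal responses), compound 3 gives the highest number of the three, 110%. Its nearest neighbour is compound 2, whose value of 95% lies beyond the scatter below it, and the furthest is compound 1, whose value of 68% lies well beyond the scatter below it. The three share one core and differ only in the ring attached to the carbonyl carbon.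

The unmeasured compound 4 `C[C@H]1C[C@@H]1C(=O)N1CC2CC(C1)N2` follows from compound 3 by a single change: 2-methylcyclopropyl in place of 2-fluorocyclopropyl on a carbonyl carbon. The ring size and the count of heavy atoms stay the same; only the fluorine gives way to a carbon. Within the data shown here, no measured pair shows this kind of exchange, so there is no direct guide to its effect in this assay.

The account expects the step of a number 12 percentage points lower from compound 3 to compound 4 (beyond the scatter) to be small, downward or none beyond the scatter. Compound 4 is therefore estimated at 98%, within a range of 72% to 120%.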

Compound 4, largest response reached (Emax), in percent of the reference or control that the assay uses: 85%
The estimate for compound 4 lay 13 percentage points above the measured number; the measured number falls inside the stated range.
By their numbers in this assay, from the lowest: compound 1; then compounds 4 and 2 (each within the scatter of the next); then compound 3.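

In this assay, 2-methylcyclopropyl in place of 2-fluorocyclopropyl on a carbonyl carbon gives a number 25 percentage points lower from compound 3 to compound 4 (beyond the scatter). This is the only step among the compounds shown in which a single place differs, and the three-membered ring, the heavy-atom count and the number of defined stereocentres all stay the same. It shows that, at this position, the maximal response depends on more than the ring itself, since exchanging the fluorine for a carbon is enough to move it beyond the scatter. Nothing at hand explains the size or direction of this step.

The compounds shown leave open how plain cyclopropyl would stand in this assay, so the step cannot yet be split into what losing the fluorine and gaining the methyl each contribute. They also leave open how a 2-chlorocyclopropyl, 2-ethylcyclopropyl or 2-hydroxymethylcyclopropyl group would respond at the same place.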